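The source may hold more compounds than are shown below. What is called first, only, known or untested is meant among the compounds shown, and "the series" means these compounds.

Compound 1: `COc1ccc2nccc(C3CN(CC4CCN(Cc5cc6ccccc6[nH]5)CC4)C(=O)O3)c2c1` — < 50200 nM
Compound 2: `COc1ccc2nccc(C3CN(C4CCN(Cc5c[nH]c6ccccc56)CC4)C(=O)O3)c2c1` — < 50200 nM

Of the compounds shown here, two have so far been tested in an in vitro functional assay on RBL cells for antagonist activity at C-C chemokine receptor type 8 (Homo sapiens), read by FLIPR and calcium flux; a lower number here means a stronger inhibitor, a higher number a weaker inhibitor. For compound 1 the reported value < 50200 nM is a limit of the assay and not a measured number. For compound 2 the reported value < 50200 nM is likewise a limit and not a number. Going by the values given here, compound 2 therefore has no fixed place on the scale: everything recorded so far rests at the limit of < 50200 nM in this assay, at which 2 of the 2 values shown sit, and no step between two measured numbers is available to lean on.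

Compound 3, `COc1ccc2nccc(C3CN(C4CCN(CCCc5ccccc5)CC4)C(=O)O3)c2c1`, differs from compound 2 in one place: phenethyl in place of 1H-indol-3-yl on a saturated chain carbon bound to an amine nitrogen in a ring. Among the compounds with values here, since no measured step exists, there is no basis for predicting a shift in either direction; the honest expectation is a step of no size beyond the scatter, and the reading may well come back as a limit again. On that basis compound 3 is expected to give 15000 nM, with a range from 1500 nM to 50000 nM. The estimated step from compound 2 to compound 3 is a step that the limit leaves unreadable from compound 2 to compound 3.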

Compound 3, half-maximal inhibitory concentration: 251 nM
For compound 3 the middle estimate is 60-fold (1.78 log units) above the measured one; measured number outside the range, below it.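

No step can be read from compound 2 to compound 3, since the value for compound 2 is a limit and not a number: the limit of < 50200 nM in this assay, at which 2 of the 3 values shown sit.

The compounds shown leave open how far apart compound 2 and compound 3 truly stand, and so what the change from (1H-indol-3-yl)methyl to 3-phenylpropyl does in this assay.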